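The source may hold more compounds than are shown below. What is called first, only, known or untested is meant among the compounds shown, and "the series" means these compounds.

Measured so far:
Compound 1, `N=C(N)NCCC[C@H](NC(=O)CN(c1nc(Cl)nc2[nH]cnc12)C1CC1)C(=O)O`: 17%
Compound 2, `O=C(OCc1ccccc1)[C@@H]1CCCN1C(=O)CN(c1ncnc2c1ncn2C1CCCCO1)C1CC1`: 17.5%
Compound 3, `O=C(CN(c1ncnc2c1ncn2C1CCCCO1)C1CC1)N[C@@H](CO)C(=O)OCc1ccccc1`: 29.2%

All three were tested in a functional assay on the whole organism (Tail, strain ICR) with Mus musculus as the target, in the tail flick test, with a stated time of 120 min, at a dose of 25 umol/kg by the oral route; on this read-out higher numbers stand for a stronger effect at the one dose given and lower numbers for a weaker effect. Compound 1 gives the lowest of the three numbers. Its nearest neighbour is compound 2, whose number lies within the usual scatter of compound 1, so the two cannot be told apart on this read-out. Compound 3 lies furthest away, and its number stands beyond the scatter above that of compound 1. No pair of these compounds differs in one place only, so no step between measured compounds is available; the values only show where each compound stands.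

Compound 4, `CC(C)[C@H](NC(=O)CN(c1nc(Cl)nc2[nH]cnc12)C1CC1)C(=O)O`, has not yet been measured in this assay. It is built from compound 1 by one change: a group of 3 heavy atoms (3 carbon; no ring) in place of a group of 7 heavy atoms (4 carbon, 3 nitrogen; no ring), on a saturated chain carbon bound to an amide-type nitrogen and a carbonyl carbon. An isopropyl enters where a group carrying three hydrogen-bond donors and one hydrogen-bond acceptor leaves; the shared core and the rest of the chain stay as they are.

Within the data shown here, nothing among the measured compounds shows how such a change moves the read-out, since no measured pair makes a comparable step. The expectation is therefore a step of a number 1 percentage points higher from compound 1 to compound 4 (within the scatter), that is, none beyond the scatter, in either direction. Compound 4 is thus estimated at 18%, with a range from 5% to 35%.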

Compound 4, a percentage reported as activity, at one dose (the size of the read-out at that dose, not a potency): 17.1%
For compound 4 the middle estimate is 0.9 percentage points above the measured one; low and high end bracket the measured number.
By their numbers in this assay, from the lowest: compounds 1, 4 and 2 (each within the scatter of the next); then compound 3.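

In this assay there is now a step between two compounds that differ in one place: a number 0.1 percentage points higher from compound 1 to compound 4 (within the scatter) for an isopropyl in place of a group of 7 heavy atoms, on a saturated chain carbon bound to an amide-type nitrogen and a carbonyl carbon. The group that leaves carries 3 hydrogen-bond donors and 1 hydrogen-bond acceptor and the isopropyl carries none, yet this read-out does not separate the two compounds, so at this dose and time the effect does not depend on which of these two groups stands at this carbon. Nothing measured here explains why the two groups cannot be told apart.

As far as these compounds go, with only these two groups compared at this carbon, it remains open whether an amine, a phenyl ring or a longer carbon chain in the same place would move the number beyond the scatter. From the compounds shown here alone, each compound was also read at a single dose, so it remains open whether compound 1 and compound 4 would still match at other doses.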